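A few compounds are considered here, and "the series" means these few. Any claim that something is new, unique, unknown or untested is made for them only; others in the source may bear on it.

Compound 1 `CC(=O)N1CC[C@H](n2c(Nc3ccccc3)nc3cnc(Nc4ccc(N5CCN(C)CC5)cc4)nc32)C1` is one of three measured analogues sharing a core that carries a substituted pyrrolidine ring; in a functional assay on HCC827 cells (Homo sapiens) for antiproliferative activity, read by MTT assay, with a stated time of 72 h (a higher number here means a weaker inhibitor, a lower number a stronger inhibitor), compound 1 gives 260 nM, the second highest of the three numbers. Compound 3 `CN1CCN(c2ccc(Nc3ncc4nc(Nc5ccc(F)cc5)n([C@@H]5CCN(C(=O)CO)C5)c4n3)cc2)CC1` gives 350 nM, a value within the scatter of compound 1, while compound 2 `CN1CCN(c2ccc(Nc3ncc4nc(Nc5ccc(F)cc5)n([C@@H]5CCN(S(=O)(=O)C6CC6)C5)c4n3)cc2)CC1` gives 2.5 nM, far stronger than either. Among the compounds with values here, the one single-point step in this assay, a 140-fold higher number from compound 2 to compound 3 (2.15 log units; beyond the scatter), shows that the group on the pyrrolidine nitrogen can move the number a long way.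

Compound 4 `CN1CCN(c2ccc(Nc3ncc4nc(Nc5ccccc5)n([C@H]5CCN(C(=O)OC(C)(C)C)C5)c4n3)cc2)CC1` differs from compound 1 at the same region: tert-butoxy in place of methyl on a carbonyl carbon. Within the data shown here, no measured pair shows exactly this exchange, and the only step at this position concerns different groups, so its direction cannot be read across directly. Given that compound 1 and compound 3, which bear different carbonyl groups on that nitrogen, sit within the scatter of each other, the expectation is a modest change, a 1.3-fold lower number from compound 1 to compound 4 (0.11 log units; within the scatter), with wide uncertainty. Compound 4 is therefore estimated at 200 nM, expected between 40 nM and 1000 nM.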

Compound 4, half-maximal inhibitory concentration: 110 nM
For compound 4 the middle estimate is 1.8-fold (0.26 log units) above the measured one, within the range that was stated.
By their numbers in this assay, from the lowest: compound 2; then compound 4; then compounds 1 and 3 (each within the scatter of the next).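

Replacing acetyl with tert-butoxycarbonyl on the amide-type nitrogen in the ring gives a 2.4-fold lower number from compound 1 to compound 4 (0.37 log units; beyond the scatter), so a change confined to the group on the carbonyl carbon is enough to shift the number, though only modestly. The earlier step at this nitrogen, rated large, exchanged a sulfonyl group for a carbonyl group, whereas this one keeps the carbonyl and shows that putting tert-butoxy in place of methyl lowers the number rather than raising it. Nothing available here explains why the number moves in this direction.

On these data alone, it remains open how this nitrogen would behave as a free amine, or when carrying a urea or a longer acyl chain. As far as these compounds go, it is also open whether cyclopropylsulfonyl would give a similarly low number on the core of compound 1.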